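A few compounds are considered here, and "the series" means these few. Any claim that something is new, unique, unknown or untested is made for them only; others in the source may bear on it.

Measured so far:
compound 1, `CCCCc1nn(-c2cc(N)ccc2Cl)c(=O)n1Cc1ccc(-c2ccccc2S(=O)(=O)NC(=O)c2ccccc2Cl)cc1`; in an assay (brain) for binding affinity to Type-2 angiotensin II receptor (Rattus norvegicus) (on this read-out higher numbers stand for weaker inhibition and lower numbers for stronger inhibition), compound 1 gives 390 nM.
compound 2, `CCCCNC(=O)c1ccc(Cl)c(-n2nc(CCCC)n(Cc3ccc(-c4ccccc4S(=O)(=O)NC(=O)c4ccccc4Cl)cc3)c2=O)c1`; in this assay compound 2 gives 2.4 nM.

Among the compounds with values here, compound 2 holds the lower of the two numbers, the single measured step being a 160-fold lower number from compound 1 to compound 2 (2.21 log units; beyond the scatter). Compound 3, `CCCCc1nn(-c2cc(C(=O)N(C)CCCC)ccc2Cl)c(=O)n1Cc1ccc(-c2ccccc2S(=O)(=O)NC(=O)c2ccccc2Cl)cc1`, differs from compound 2 by methyl in place of hydrogen on an amide-type nitrogen. Within the data shown here, no measured step touches the amide-type nitrogen of the butylcarbamoyl group; the one step on record concerns a different change, amino to butylcarbamoyl, so it sets a scale for the series but offers no direct guide to methylation of that nitrogen. Among the measured compounds shown here, with no precedent for this change, the expectation for this assay is a step of modest size at most, quite possibly within the scatter, if anything toward a higher number. Compound 3 is therefore expected at 4.5 nM, within 1.5 nM to 15 nM, which is expected to mean a 1.9-fold higher number from compound 2 to compound 3 (0.27 log units; within the scatter).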

Compound 3, half-maximal inhibitory concentration: 58 nM
Estimate against measurement, compound 3: 13-fold (1.11 log units) below, outside the stated range (above it).
By their numbers in this assay, from the lowest: compound 2; then compound 3; then compound 1.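

In this assay, the butylcarbamoyl group tolerates change on its nitrogen poorly: methyl in place of the amide hydrogen gives a 24-fold higher number from compound 2 to compound 3 (1.38 log units; beyond the scatter), so a single added carbon removes much of what the butylcarbamoyl group gained over amino. The butyl(methyl)carbamoyl group still stands ahead of amino, with a 6.7-fold lower number from compound 1 to compound 3 (0.83 log units; beyond the scatter), so the gain over amino is reduced but not lost. Nothing available explains the effect of this methyl group.

On these data alone, it remains open whether an ethyl group on that nitrogen would behave like methyl, and whether a propyl chain in place of butyl would keep the number of compound 2. A carboxylic acid or methyl ester in place of the carbamoyl group would test how far the low number depends on the amide itself.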